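Pyridin-3-yl in place of ethynyl: working notes

This account rests on a few compounds, and the source may have more. Where it says the series, first, only, none or still open, it means among the compounds named here.

Values in a functional assay with Mus musculus as the target (on this read-out lower numbers stand for stronger inhibition and higher numbers for weaker inhibition), follow
- compound 1 `O=C(O)C[C@H](NC(=O)CN1CCCC(CCc2ccc3c(n2)NCCC3)C1=O)c1cccnc1` gives 480 nM
- compound 2 `O=C(O)C[C@H](NC(=O)CN1CC[C@@H](CCc2ccc3c(n2)NCCC3)C1=O)c1cccnc1` gives 79 nM
- compound 3 `C#C[C@H](CC(=O)O)NC(=O)CN1CC[C@H](CCc2ccc3c(n2)NCCC3)C1=O` gives 150 nM

In this assay compound 3 (150 nM) holds the middle place of the three numbers. It lies within the scatter of compound 2 and beyond the scatter from compound 1, which has the higher number. In compound 4 `O=C(O)C[C@H](NC(=O)CN1CC[C@H](CCc2ccc3c(n2)NCCC3)C1=O)c1cccnc1`, pyridin-3-yl stands in place of ethynyl on a saturated chain carbon bound to an amide-type nitrogen and a saturated chain carbon (pyridin-3-yl in place of ethynyl on a saturated chain carbon bound to an amide-type nitrogen and a saturated chain carbon). Pyridin-3-yl also occurs in compound 1 (480 nM) and in compound 2 (79 nM), so the values set no firm direction. The expected 1.5-fold lower number from compound 3 to compound 4 (0.18 log units; within the scatter) is small and is not anticipated to exceed the scatter. Compound 4 is estimated at 100 nM, with an expected range from 25 nM to 400 nM in this read-out.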

Compound 4, half-maximal inhibitory concentration: 62 nM
For compound 4 the middle estimate is 1.6-fold (0.21 log units) above the measured one; measured number inside the range.
By their numbers in this assay, from the lowest: compounds 4, 2 and 3 (each within the scatter of the next, the first and the last beyond it); then compound 1.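

In this assay, within the data shown here, pyridin-3-yl in place of ethynyl on the saturated chain carbon gives a 2.4-fold lower number from compound 3 to compound 4 (0.38 log units; beyond the scatter), a reading of this change in one place that the earlier compounds did not allow. The stereocentre at the saturated ring carbon gives a 1.3-fold lower number from compound 2 to compound 4 (0.11 log units; within the scatter), so this read-out does not separate the R and S forms as drawn. This comparison is clean on one point: the fact that compounds 2 and 4 differ only in the configuration as drawn

On these data alone, how phenyl or a longer chain would read at the same position remains open. Also open, as far as these compounds go, is whether the ethynyl to pyridin-3-yl step carries over to the R configuration.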